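The compounds below may be only part of what the source reports. "The series", "measured", "known", "first", "only" and "open" are said of these compounds alone.

Compound 1 `OC(c1ccc(Cl)cc1)(c1cccnc1)c1ccccc1F`: > 100000 nM (a limit)
Compound 2 `OC(c1ccc(Cl)cc1)(c1cccnc1)c1ccccc1Br`: 55200 nM

Both compounds were read in an ADME assay on L6 cells (Rattus norvegicus) for cytotoxicity, read by resazurin assay, with a stated time of 72 h; a higher number here means a weaker inhibitor, a lower number a stronger inhibitor. Among the compounds with values here, compound 2, at 55200 nM, holds the only true number so far. Compound 1 stands at the limit of > 100000 nM in this assay, at which 1 of the 2 values shown sits.

Compound 3 `OC(c1ccc(Cl)cc1)(c1cccnc1)c1ccsc1` has not yet been measured in this assay. It differs from compound 2 by thiophen-3-yl in place of 2-bromophenyl on a saturated chain carbon bound to two aromatic carbons and an oxygen on a saturated carbon: thiophen-3-yl in place of 2-bromophenyl. Within the data shown here, only one measured step bears on this, and only loosely, an at least 1.8-fold lower number from compound 1 to compound 2 (0.25 log units; that floor lies within the scatter). That step concerns the same aryl group but not a change of ring, and its floor lies within the scatter. No step beyond the scatter is therefore expected, though any drift would be toward a higher number, since the bromo group of compound 2 is lost. The estimated step is a 1.4-fold higher number from compound 2 to compound 3 (0.16 log units; within the scatter). For compound 3 the expected value is 80000 nM, with an estimated range of 35000 nM to 160000 nM.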

Compound 3, half-maximal inhibitory concentration: > 100000 nM
Compound 3 gave a limit, no number (the forecaster's own chance of this, stated with the estimate: 45%); at least 1.2-fold (0.09 log units) between middle value and limit.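

In this assay, thiophen-3-yl in place of 2-bromophenyl on the saturated chain carbon gives an at least 1.8-fold higher number from compound 2 to compound 3 (0.25 log units; that floor lies within the scatter). Within the data shown here, this is the first change of the whole ring at this place, not only of the halogen it carries, and compound 3 gives a limit rather than a number, so compound 2 remains the only compound with a true value: the limit of > 100000 nM in this assay, at which 2 of the 3 values shown sit. The step between compound 1 and compound 3 cannot be read, as both values are limits.

The true size of the steps to and from compound 2 remains open, and with floors inside the scatter, the compounds shown do not establish a real difference from compound 2 in either case. Also open, going by these compounds, is what an aminomethyl group or a carboxylic acid on the ring at this place would give in this assay.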